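The compounds below may be only part of what the source reports. "The series", "measured", "known", "first", "only" and "open" are said of these compounds alone.

Going by the values given here, compound 1 `O=C(Nc1ccc(O)cc1)C1CCc2ccccc2N1` and compound 2 `O=C(Nc1ccccc1O)C1CCc2ccccc2N1C(=O)c1ccccc1` are the two measured members. In a functional assay on NCI-H23 cells (Homo sapiens) for cytotoxicity, read by sulforhodamine B assay, with a stated time of 72 h (on this read-out higher numbers stand for weaker inhibition of growth and lower numbers for stronger inhibition of growth), compound 1 is recorded only as a limit, > 100000 nM, so its standing is known no closer than that (the limit of > 100000 nM in this assay, at which 1 of the 2 values shown sits). In this assay compound 2 gives 3490 nM; its structure differs from compound 1 in more than one place, so that gap is not assigned to any single change. Compound 3 `O=C(Nc1ccccc1)C1CCc2ccccc2N1` is still to be measured. It arises from compound 1 by hydrogen in place of hydroxy on an aromatic carbon. No step beyond the scatter is expected in this assay. Compound 3 is estimated at 100000 nM, ranging from 30000 nM to 300000 nM. The step of a number no higher from compound 1 to compound 3 (the limit leaves the size open) is what this expectation implies.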

Compound 3, concentration for 50% growth inhibition: 97100 nM
Compound 3: the middle estimate sits 1.0-fold (0.01 log units) above what was measured; measured number inside the range.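

In this assay compound 3 gives 97100 nM, so hydrogen on this aromatic carbon, para to a large group, now has a measured number. Hydrogen in place of hydroxy gives an at least 1.0-fold lower number from compound 1 to compound 3 (0.01 log units; that floor lies within the scatter). That floor shows no effect of the hydroxy here, and the true size of the step stays unknown because compound 1 is only a limit: the limit of > 100000 nM in this assay, at which 1 of the 3 values shown sits.

As far as these compounds go, whether an amine or a carboxylic acid on this carbon would move the number stays open. The compounds shown also do not separate the changes that set compound 2 apart from compound 3.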